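Trimming a Sulfonamide to an Amino Group: Expected Stability

A few compounds are considered here, and "the series" means these few. Any claim that something is new, unique, unknown or untested is made for them only; others in the source may bear on it.

Measured compounds:
Compound 1, `O=S(=O)(c1cccc(-c2ccc3nccc(-c4ccncc4)c3n2)c1)N1CCC(O)CC1`: 5%
Compound 2, `O=S(=O)(NCCO)c1cccc(Nc2ccc3nccc(-c4ccncc4)c3n2)c1`: 59%

Of the compounds shown here, two have been measured in an ADME assay on microsomes from liver (Homo sapiens) for metabolic stability, read by LC-MS, using NADPH, with a stated time of 30 min, tested at 0.1 uM; a higher number here means that more of the compound is left, a lower number that less of the compound is left. Compound 1 gives 5% in this assay, the lowest of the two numbers; compound 2 gives 59%, which lies beyond the scatter above it. Among the compounds with values here, compounds 1 and 2 differ in more than one place, so no single step between them can be drawn.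

The compound not yet measured is compound 3, `Nc1cccc(-c2ccc3nccc(-c4ccncc4)c3n2)c1`. It differs from compound 1 at one place: amino in place of (4-hydroxypiperidin-1-yl)sulfonyl on an aromatic carbon. Within the data shown here, no measured pair shows this change, so nothing measured tells how this assay responds to it. Since compound 1 gives 5%, almost all of it is gone within the stated time, leaving room only for the number to stay low or to rise. For compound 3 a moderate rise, uncertain in size, is expected, a number 20 percentage points higher from compound 1 to compound 3 (beyond the scatter), giving an estimated 25% with a range from 5% to 60%.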

Compound 3, percent of the compound remaining: 78%
Estimate against measurement, compound 3: 53 percentage points below; the measured number lies above the stated range.
By their numbers in this assay, from the lowest: compound 1; then compound 2; then compound 3.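

On an aromatic carbon meta to a large group, amino in place of (4-hydroxypiperidin-1-yl)sulfonyl has a large effect in this assay: a number 73 percentage points higher from compound 1 to compound 3 (beyond the scatter). Within the data shown here, the change removes 10 heavy atoms and adds 1, and it shows that the core of compound 1, carrying only this small group, can remain largely intact, with compound 3 at 78%. Nothing available explains why the number rises.

The whole group changes in this one step, so the compounds shown do not separate the parts played by the sulfonyl, the six-membered ring and its hydroxy group. Also open, on these data alone, is how a methylsulfonyl group, a piperidin-1-ylsulfonyl group without the hydroxy group, or a carboxylic acid on the same carbon would compare.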